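Adding a Third Fluorine to a Difluoromethyl Group

The source may hold more compounds than are shown below. What is called first, only, known or untested is meant among the compounds shown, and "the series" means these compounds.

Compound 1 `N#Cc1ncncc1-c1nc2cc(F)c(F)cc2n1C1CC1`: 4990 nM
Compound 2 `N#Cc1ccc2nc(-c3cncnc3C(F)F)n(C3CC3)c2n1`: 3930 nM

In an ADME assay on cells for inhibition of cytochrome P450 11B1, mitochondrial (Homo sapiens), read by HPLC, with a stated time of 60 min (a higher number here means a weaker inhibitor, a lower number a stronger inhibitor), compound 2 gives the lowest of the two numbers, yet compound 1 lies within the scatter of it, so the two cannot be told apart. Compound 3 `N#Cc1ccc2nc(-c3cncnc3C(F)(F)F)n(C3CC3)c2n1` differs from compound 2 by fluoro in place of hydrogen on a saturated chain carbon bound to an aromatic carbon and two fluorine atoms. Among the compounds with values here, no measured pair shows this kind of change, so no step can be read off. The expected step from compound 2 to compound 3, a 1.1-fold lower number from compound 2 to compound 3 (0.05 log units; within the scatter), is small, with no clear direction and not beyond the scatter. Compound 3 is therefore expected at 3500 nM, with a range from 1500 nM to 9000 nM.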

Compound 3, half-maximal inhibitory concentration: 4810 nM
For compound 3 the middle estimate is 1.4-fold (0.14 log units) below the measured one; the measured number falls inside the stated range.
By their numbers in this assay, from the lowest: compounds 2, 3 and 1 (each within the scatter of the next).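

Within the data shown here, replacing difluoromethyl with trifluoromethyl gives a 1.2-fold higher number from compound 2 to compound 3 (0.09 log units; within the scatter) in this assay and is the first single change that can be read. At this carbon, the third fluorine leaves the two compounds indistinguishable. Nothing measured here offers an explanation for this result.

On these data alone, whether a different kind of group at this place, such as an amine or a carboxylic acid, would move the number beyond the scatter remains open. Also open, as far as these compounds go, is whether the same change would read alike on another core.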